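The source may report more compounds than this note shows. Statements on the series, on what has been measured and on what is new or still open speak of the compounds shown alone.

In a functional assay on MCF7 cells (Homo sapiens) for inhibition, read by MTT assay, with a stated time of 72 h (a higher number here means a weaker inhibitor, a lower number a stronger inhibitor), three compounds have been measured so far. Compound 1 `COc1cc(OC)c(-c2cc(=O)c3ccc(O)cc3o2)cc1OC` gives > 150000 nM, which is a limit of the assay and not a number. Among the measured compounds shown here, compound 2 `COc1cc(OC)c(OC)cc1/C=C/C(=O)c1cc(Cc2ccccc2)cc(Cc2ccccc2)c1` gives 23300 nM, the only true number in the set. Compound 3 `COc1cc(OC)c(OC)cc1/C=C/C(=O)c1ccccc1` gives > 150000 nM, which is also a limit and not a number. Compound 3 therefore has no exact position, and the same holds for compound 1: the limit of > 150000 nM in this assay, at which 2 of the 3 values shown sit.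

Compound 4 `COc1cc(OC)c(OC)cc1/C=C/C(=O)c1ccc(C)cc1` is made from compound 3 by one small edit: methyl in place of hydrogen on an aromatic carbon. This places methyl in place of hydrogen on an aromatic carbon, para to a large group. For the measured compounds named here, no measured pair shows what this edit does, so the expectation in this assay is no step beyond the usual scatter. That expectation starts from compound 3 with its limit of > 150000 nM. The expected change is an at least 1.2-fold lower number from compound 3 to compound 4 (0.09 log units; that floor lies within the scatter). A second limit instead of a number is quite possible. The estimate for compound 4 is 120000 nM, with an expected range from 50000 nM to 250000 nM.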

Compound 4, half-maximal inhibitory concentration: 33000 nM
Compound 4: middle estimate off by 3.6-fold (0.56 log units), on the high side; measured number below the stated range.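

In this assay, this pair gives the first direct view of what one small edit does: methyl in place of hydrogen on the aromatic ring, para to a large group, is enough to give a true number instead of a limit. The change is an at least 4.5-fold lower number from compound 3 to compound 4 (0.65 log units; beyond the scatter). That size is only a floor and the real step could be larger, because compound 3 carries a limit and not a number: the limit of > 150000 nM in this assay, at which 2 of the 4 values shown sit.

The compounds shown leave open whether methyl is special here, since the result of an ethyl chain, a methoxy group or an amine at this place is unknown. Also open, going by these compounds, is whether the same edit would give a step of similar size on the core of compound 2.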